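Trading a Halogenated Ring for Dimethylphenyl

A few compounds are considered here, and "the series" means these few. Any claim that something is new, unique, unknown or untested is made for them only; others in the source may bear on it.

Among the compounds with values here, compound 2 `Cc1oc(-c2c(Cl)cccc2C(F)(F)F)nc1CN1CCC(C(=O)NCCCN2C[C@H](C)C[C@H](C)C2)CC1` holds the only plain number in an ADME assay on microsomes from liver (Rattus norvegicus) for metabolic stability, read by LC-MS, using NADPH, at 37 degrees C (on this read-out higher numbers stand for a longer-lived compound and lower numbers for a shorter-lived compound), giving 0.03 h. Compound 1 `Cc1cc(C)c(-c2nc(CN3CCC(C(=O)NCCCN4C[C@H](C)C[C@H](C)C4)CC3)c(C)o2)c(C)c1` reaches only a limit in this assay, > 0.5 h, as recorded in the limit of > 0.5 h in this assay, at which 1 of the 2 values shown sits. Within the data shown here, the single measured step, an at least 16-fold lower number from compound 1 to compound 2 (1.22 log units; beyond the scatter), runs the opposite way from the change now considered. Compound 3 `Cc1ccc(-c2nc(CN3CCC(C(=O)NCCCN4C[C@H](C)C[C@H](C)C4)CC3)c(C)o2)c(C)c1` arises through (2,4-dimethylphenyl in place of 2-chloro-6-(trifluoromethyl)phenyl on an aromatic carbon). Because that step an at least 16-fold lower number from compound 1 to compound 2 (1.22 log units; beyond the scatter) was large, and 2,4-dimethylphenyl closely resembles 2,4,6-trimethylphenyl, a large rise is expected, a 13-fold higher number from compound 2 to compound 3 (1.12 log units; beyond the scatter). Compound 3 is therefore estimated at 0.4 h, within 0.1 h to 1.5 h, and may again reach only a limit.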

Compound 3, half-life: > 0.5 h
Compound 3: a limit, no number (the forecaster's own chance of this, stated with the estimate: 45%); middle value at least 1.2-fold (0.09 log units) away from the limit.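

In this assay, 2,4-dimethylphenyl in place of 2-chloro-6-(trifluoromethyl)phenyl gives an at least 16-fold higher number from compound 2 to compound 3 (1.22 log units; beyond the scatter). The large difference from the halogenated ring therefore appears with a second methylated ring, one that has a methyl fewer than 2,4,6-trimethylphenyl. The step between compound 1 and compound 3 cannot be read, because each value is a limit and not a number: the limit of > 0.5 h in this assay, at which 2 of the 3 values shown sit.

As far as these compounds go, their true half-lives remain open. So does whether a phenyl ring carrying only chlorine, or only trifluoromethyl, would give a short half-life like that of compound 2.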